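This account rests on a few compounds, and the source may have more. Where it says the series, first, only, none or still open, it means among the compounds named here.

The measured compounds and their values in a functional assay on A549 cells (Homo sapiens) for antiproliferative activity, read by spectrophotometry, with a stated time of 2 days (a lower number here means a stronger inhibitor of growth, a higher number a weaker inhibitor of growth), are these.
Compound 1 `CN(c1cccc2c1CN(c1nc(Nc3ccc(C(F)(F)F)cc3)ncc1C(F)(F)F)C2)S(C)(=O)=O` gives > 30000 nM, which is a limit of the assay rather than a number.
Compound 2 `CN(c1cccc2c1CN(c1nc(Nc3cccc(C(F)(F)F)c3)ncc1C(F)(F)F)C2)S(C)(=O)=O` gives > 30000 nM, again a limit of the assay and not a number.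
Compound 3 `CN(c1cccc2c1CN(c1nc(Nc3cccc(Oc4ccccc4)c3)ncc1C(F)(F)F)C2)S(C)(=O)=O` gives 19000 nM.

Compound 2 thus stands at the limit of > 30000 nM in this assay, at which 2 of the 3 values shown sit, so no number is known for it, only a ceiling. Of the two measured steps, a step that the two limits leave unreadable from compound 1 to compound 2 tells nothing, and an at least 1.5-fold lower number from compound 2 to compound 3 (0.19 log units; that floor lies within the scatter) shows the only readable movement, a small one in the direction of stronger growth inhibition.

Compound 4 `Cc1cc(F)ccc1Nc1ncc(C(F)(F)F)c(N2Cc3cccc(N(C)S(C)(=O)=O)c3C2)n1` differs from compound 2 by 4-fluoro-2-methylphenyl in place of 3-(trifluoromethyl)phenyl on a nitrogen on an aromatic ring. Neither measured step covers this particular exchange, so the expectation rests on the weak level of the whole series: compound 4 is expected to remain a weak inhibitor, with an at least 1.0-fold lower number from compound 2 to compound 4 (0.02 log units; that floor lies within the scatter) as the estimated step and a fair chance that the assay again reports only a limit. The estimate for compound 4 is 28000 nM, in the range 9000 nM to 60000 nM.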

Compound 4, concentration for 50% growth inhibition: > 30000 nM
Compound 4: a limit, no number; the forecaster's own chance of this, stated with the estimate: 55%; at least 1.0-fold (0.02 log units) between middle value and limit.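

Compound 4 gives > 30000 nM in this assay, which is a limit of the assay and not a number, so its steps from compound 1 and compound 2, both also at limits, cannot be read. The compounds shown leave open whether exchanging these aryl groups on the nitrogen changes growth inhibition at all.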